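Dropping the Chloro Group: From Compound 3 to Compound 4

The source may report more compounds than this note shows. Statements on the series, on what has been measured and on what is new or still open speak of the compounds shown alone.

Measured compounds:
compound 1, `CCN(CC)CN1C(=O)/C(=N\c2nc3ccc(C)cc3s2)c2c(Br)cccc21`, 28700 nM
compound 2, `Cc1ccc2nc(/N=C3\C(=O)N(CN4CCCCC4)c4ccccc43)sc2c1`, 34500 nM
compound 3, `O=C1C(=O)N(CN(c2ccccc2)c2ccccc2)c2cccc(Cl)c21`, 31400 nM

All three compounds were tested in a functional assay on MDA-MB-231 cells (Homo sapiens) for cytotoxicity, read by sulforhodamine B assay, with a stated time of 48 h; on this read-out lower numbers stand for stronger inhibition of growth and higher numbers for weaker inhibition of growth. Compound 1 gives 28700 nM, compound 2 gives 34500 nM, and compound 3 gives 31400 nM. Compound 3 holds the second highest of the three numbers, with compound 1 nearest and compound 2 furthest, yet both of those gaps lie within the usual scatter, so the three compounds cannot be set apart from one another on this read-out.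

Compound 4, `O=C1C(=O)N(CN(c2ccccc2)c2ccccc2)c2ccccc21`, differs from compound 3 in one place: hydrogen in place of chloro on an aromatic carbon. Within the data shown here, no pair of measured compounds shows a single change of this kind, so there is no measured step to lean on. Given that the three measured compounds sit together within the scatter, a small shift, if any, toward a higher number is expected, most likely not beyond the scatter. Compound 4 is therefore estimated at 40000 nM, with a range from 15000 nM to 100000 nM, which corresponds to an expected step of a 1.3-fold higher number from compound 3 to compound 4 (0.11 log units; within the scatter).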

Compound 4, concentration for 50% growth inhibition: 24800 nM
For compound 4 the middle estimate is 1.6-fold (0.21 log units) above the measured one, within the range that was stated.
By their numbers in this assay, from the lowest: compounds 4, 1, 3 and 2 (each within the scatter of the next).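

In this assay, among these compounds, the replacement of chloro by hydrogen on an aromatic carbon gives a 1.3-fold lower number from compound 3 to compound 4 (0.10 log units; within the scatter), and this is the first single change that can be read directly. It shows that, with the rest of compound 3 held constant, the chloro group at this place can be lost without a change in growth inhibition that stands out from the scatter. The data offer no measurement that would explain this result.

Still open, going by these compounds, is whether a larger or different group at this place, such as methoxy or an amine, would move the number beyond the scatter. On these data alone, it also remains open whether the same exchange would give a similarly small step on the core of compound 1.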